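The source may report more compounds than this note shows. Statements on the series, on what has been measured and on what is new or still open speak of the compounds shown alone.

Measured compounds:
compound 1 `Fc1cccc(-c2nc(Nc3ccccc3F)c3cc(F)ccc3n2)c1`, > 50000 nM
compound 2 `Fc1cccc(-c2nc(Nc3ccc(Cl)cc3)c3cc(F)ccc3n2)c1`, 38400 nM

Among the measured compounds shown here, compound 2 holds the only number in a functional assay on U2OS cells (Homo sapiens) for cytotoxicity, read by MTT assay, with a stated time of 48 h; a higher number here means a weaker inhibitor, a lower number a stronger inhibitor; the other value shown is a limit. Compound 1 sits at the limit of > 50000 nM in this assay, at which 1 of the 2 values shown sits, a limit of the assay rather than a number. For the measured compounds named here, the single measured step, an at least 1.3-fold lower number from compound 1 to compound 2 (0.11 log units; that floor lies within the scatter), bears on compound 3 `Fc1cccc(-c2nc(Nc3ccccc3Cl)c3cc(F)ccc3n2)c1`, which differs from compound 2 by 2-chlorophenyl in place of 4-chlorophenyl on a nitrogen on an aromatic ring. Compound 3 carries 2-chlorophenyl where compound 1 carries 2-fluorophenyl, and the measured step ran the other way. A higher number is therefore expected, a 1.6-fold higher number from compound 2 to compound 3 (0.19 log units; within the scatter), possibly back to a limit. For compound 3 the estimate is 60000 nM, range 25000 nM to 150000 nM.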

Compound 3, half-maximal inhibitory concentration: > 50000 nM
Compound 3 was reported as a limit (the forecaster's own chance of this, stated with the estimate: 55%); the middle value does not contradict the limit.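

In this assay, 2-chlorophenyl in place of 4-chlorophenyl on the nitrogen gives an at least 1.3-fold higher number from compound 2 to compound 3 (0.11 log units; that floor lies within the scatter), so compound 3 is not separated from compound 2. The result for compound 3 is a limit, not a number, and 2-chlorophenyl now stands with 2-fluorophenyl at that limit: the limit of > 50000 nM in this assay, at which 2 of the 3 values shown sit. The step from compound 1 to compound 3, chloro in place of fluoro, cannot be read because both values are limits.

Still open, as far as these compounds go, is whether a phenyl carrying methoxy or dimethylamino on this nitrogen would give a readable number in this assay.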